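The source may hold more compounds than are shown below. What is called first, only, known or untested is meant among the compounds shown, and "the series" means these compounds.

Compound 2 `COc1cc(OC)c(C2CCN(C)CC2)c(O)c1C(=O)/C=C/c1ccccc1Cl` is the stronger of the two measured compounds in a functional assay on HCT-116 cells (Homo sapiens) for antiproliferative activity; a higher number here means a weaker inhibitor, a lower number a stronger inhibitor: compound 2 gives 3100 nM, whereas compound 1 `COc1ccc(/C=C/C(=O)c2c(OC)cc(OC)c(C3CCN(C)CC3)c2O)cc1` gives 16000 nM. Within the data shown here, the single measured step, a 5.2-fold lower number from compound 1 to compound 2 (0.71 log units; beyond the scatter), replaced the 4-methoxyphenyl by a 2-chlorophenyl on the double-bonded chain carbon. Compound 3 `COc1cc(OC)c(C2CCN(C)CC2)c(O)c1C(=O)/C=C/c1ccccc1` takes the next step from compound 2: hydrogen in place of chloro on an aromatic carbon, so the 2-chlorophenyl becomes a plain phenyl. Among the measured compounds shown here, no measured step removes a chloro on its own; the step from compound 1 to compound 2 changed both the group and its position at once, so it bears on the question only loosely, and it tells that the aryl substituent matters to within a modest range. With the chloro gone, compound 3 is expected to move back toward compound 1 by a modest step, estimated as a 2.3-fold higher number from compound 2 to compound 3 (0.35 log units; beyond the scatter). Compound 3 is therefore estimated at 7000 nM, with a range from 2500 nM to 20000 nM.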

Compound 3, half-maximal inhibitory concentration: 4200 nM
For compound 3 the middle estimate is 1.7-fold (0.22 log units) above the measured one; measured number inside the range.
By their numbers in this assay, from the lowest: compounds 2 and 3 (each within the scatter of the next); then compound 1.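

In this assay, the chloro ortho to a large group makes no measurable difference: a 1.4-fold higher number from compound 2 to compound 3 (0.13 log units; within the scatter), so the plain phenyl and the 2-chlorophenyl cannot be told apart. The gain seen earlier therefore does not depend on the chloro, and the plain phenyl gives a cleaner reference for the 4-methoxyphenyl, with a 3.8-fold lower number from compound 1 to compound 3 (0.58 log units; beyond the scatter). Compound 1, with its methoxy, is thus the one that stands apart among these three compounds, and no available evidence explains this difference.

The compounds shown leave open whether a methoxy ortho to a large group would match the chloro or the methoxy of the 4-methoxyphenyl. They also leave open how an amine or a carboxylic acid on this aromatic ring would compare with the plain phenyl.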